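Swapping pyrimidin-5-yl for phenyl on the shared core

This account rests on a few compounds, and the source may have more. Where it says the series, first, only, none or still open, it means among the compounds named here.

For the measured compounds named here, in a functional assay on VCaP cells (Homo sapiens) for antiproliferative activity, read by CCK-8 assay, with a stated time of 6 days (a higher number here means a weaker inhibitor, a lower number a stronger inhibitor), compound 1 (`CCN(c1ccc(C#N)c(Cl)c1)c1cc(-n2cnc3ccccc32)ccc1C`) gives 8560 nM and compound 2 (`CCN(c1ccc(C#N)c(Cl)c1)c1cc(-c2cncnc2)ccc1C`) gives 3920 nM as the lower of the two numbers so far. Compound 3 (`CCN(c1ccc(C#N)c(Cl)c1)c1cc(-c2ccccc2)ccc1C`) carries phenyl in place of pyrimidin-5-yl on an aromatic carbon. Going by the values given here, the one measured change at this site, pyrimidin-5-yl in place of 1H-benzimidazol-1-yl, gave a 2.2-fold lower number from compound 1 to compound 2 (0.34 log units; beyond the scatter) and was modest. In this assay a step no larger is therefore expected, with no firm direction. The estimated step is a 1.1-fold lower number from compound 2 to compound 3 (0.05 log units; within the scatter) and so none beyond the scatter is expected. Compound 3 is expected near 3500 nM within a range from 1300 nM to 9000 nM in this estimate.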

Compound 3, half-maximal inhibitory concentration: > 30000 nM
Compound 3 gave a limit, no number; the forecaster's own chance of this, stated with the estimate: 5%; at least 8.5-fold (0.93 log units) between middle value and limit.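

In this assay, replacing the two ring nitrogens of pyrimidin-5-yl with carbon while keeping the six-membered aromatic ring gives an at least 7.6-fold higher number from compound 2 to compound 3 (0.88 log units; beyond the scatter), so this position responds clearly to a change of ring atoms alone. Phenyl in place of 1H-benzimidazol-1-yl gives an at least 3.5-fold higher number from compound 1 to compound 3 (0.54 log units; beyond the scatter), so phenyl also compares unfavourably with the larger group. Compound 3 gave a limit and not a number: the limit of > 30000 nM in this assay, at which 1 of the 3 values shown sits.

From the compounds shown here alone, the true size of both steps therefore stays open. It is also unknown whether pyridin-3-yl or an amine at this position would give a lower number than pyrimidin-5-yl.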